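Aryl sulfamate series: amine chain at the meta amide position

This account rests on a few compounds, and the source may have more. Where it says the series, first, only, none or still open, it means among the compounds named here.

Measured so far in an assay on HEK293 cells for inhibition of Steryl-sulfatase (Homo sapiens), tested at 1 uM; a higher number here means a stronger effect of the compound at the concentration tested, a lower number a weaker effect:
compound 1 `CN(C)CCN(CCN(C)C)c1ccc(C(=O)N2CCc3ccc(OS(N)(=O)=O)cc3C2)cc1` gives 15.9%
compound 2 `CCN(Cc1ccc(F)cc1)c1ccc(C(=O)N2CCc3ccc(OS(N)(=O)=O)cc3C2)cc1` gives 91.2%
compound 3 `CCN(Cc1ccc(F)cc1)c1cccc(C(=O)N2CCc3ccc(OS(N)(=O)=O)cc3C2)c1` gives 66.5%

Compound 3 stands second of the three numbers: compound 2 lies above it and compound 1 below it, both gaps beyond the scatter. Compound 4 `CN(CCN1CCCCC1)c1cccc(C(=O)N2CCc3ccc(OS(N)(=O)=O)cc3C2)c1` differs from compound 3 in one place: methyl(2-(piperidin-1-yl)ethyl)amino in place of ethyl(4-fluorobenzyl)amino on an aromatic carbon. For the measured compounds named here, the only measured step that bears on this, a number 75.3 percentage points higher from compound 1 to compound 2 (beyond the scatter), runs the opposite way, with ethyl(4-fluorobenzyl)amino entering and an amine-bearing chain leaving. Here the benzyl-bearing group leaves and a chain carrying a piperidin-1-yl nitrogen enters, so a large downward step in this assay is expected, a number 41.5 percentage points lower from compound 3 to compound 4 (beyond the scatter). Compound 4 is therefore estimated at 25%, with a range from 5% to 55%.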

Compound 4, a percentage reported as inhibition, at one concentration (the size of the read-out at that concentration, not a potency): 30.8%
The estimate for compound 4 lay 5.8 percentage points below the measured number; low and high end bracket the measured number.
By their numbers in this assay, from the lowest: compound 1; then compound 4; then compound 3; then compound 2.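

Replacing ethyl(4-fluorobenzyl)amino with methyl(2-(piperidin-1-yl)ethyl)amino on the aromatic carbon meta to a large group gives, in this assay, a number 35.7 percentage points lower from compound 3 to compound 4 (beyond the scatter). Read with a number 75.3 percentage points higher from compound 1 to compound 2 (beyond the scatter), this places the ethyl(4-fluorobenzyl)amino compound higher in both pairs, even though the amine-bearing chains differ and the two pairs carry their groups at different ring positions. No measurement shown accounts for this drop.

Still open, on these data alone, is whether the fluorine or the benzyl group itself carries the difference. A plain benzylamine, or a morpholine in place of the piperidine, would help separate these.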